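Swapping Dichlorophenyl for Methoxyphenyl: Expected Cell Tolerance

The source may report more compounds than this note shows. Statements on the series, on what has been measured and on what is new or still open speak of the compounds shown alone.

Compound 3 `COC(=O)c1cc(-c2cccc(NC(=O)c3ccc(/C=C/C(=O)c4ccc(Cl)cc4Cl)cc3)c2)on1` carries a 2,4-dichlorophenyl on a carbonyl carbon. In an ADME assay on Vero cells (Chlorocebus sabaeus) for cytotoxicity, read by MTT assay, with a stated time of 72 h (a lower number here means that less compound is tolerated, a higher number that more compound is tolerated), compound 3 gives only a limit of the assay, > 40 ug/mL. Compound 2 `COC(=O)c1cc(-c2cccc(NC(=O)c3ccc(/C=C/C(=O)c4cc(F)ccc4F)cc3)c2)on1` differs from it in that place. In this assay compound 2 likewise gives only a limit, > 40 ug/mL. Compound 1 `COC(=O)c1cc(-c2cccc(NC(=O)c3ccc(/C=C/C(=O)c4cccnc4)cc3)c2)on1` gives "not determined" (no result reported) in this assay, so no number exists for it. The step that the two limits leave unreadable from compound 2 to compound 3 cannot be read because both compounds sit at the limit of > 40 ug/mL in this assay, at which 2 of the 3 values shown sit.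

Compound 4 `COC(=O)c1cc(-c2cccc(NC(=O)c3ccc(/C=C/C(=O)c4ccccc4OC)cc3)c2)on1` differs from compound 3 by 2-methoxyphenyl in place of 2,4-dichlorophenyl on a carbonyl carbon. With no readable step among the measured compounds, no shift beyond the usual scatter is expected in this assay. Compound 4 is therefore estimated to give 45 ug/mL, between 25 ug/mL and 90 ug/mL, an expected step that the limit leaves unreadable from compound 3 to compound 4.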

Compound 4, half-maximal cytotoxic concentration: > 40 ug/mL
Compound 4 gave a limit, no number; the forecaster's own chance of this, stated with the estimate: 70%; the middle value does not contradict the limit.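

The steps from compound 2 and from compound 3 to compound 4 cannot be read, because all three compounds sit at a limit: the limit of > 40 ug/mL in this assay, at which 3 of the 4 values shown sit.

The compounds shown leave open whether the groups on the carbonyl carbon differ at all in this assay.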